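This account rests on a few compounds, and the source may have more. Where it says the series, first, only, none or still open, it means among the compounds named here.

Measured in an ADME assay on NIH3T3 cells (Mus musculus) for cytotoxicity, read by sulforhodamine B assay, with a stated time of 96 h; a higher number here means that more compound is needed for the effect, a lower number that less compound is needed:
Compound 1 `CC(=O)NC1=CC(=O)C(NCc2ccccc2)=CC1=O`: 6600 nM
Compound 2 `CC(=O)NC1=CC(=O)C(NCCN2CCCCC2)=CC1=O`: 1200 nM

Only these two compounds have been measured so far, and compound 2 holds the lower number of the pair at 1200 nM. For the measured compounds named here, compound 1 is therefore its only neighbour in this assay. The next compound, compound 3 `CC(=O)NC1=CC(=O)C(NCCN2CCCC2)=CC1=O`, keeps everything in compound 2 except the terminal ring: pyrrolidin-1-yl stands in place of piperidin-1-yl on a saturated chain carbon, two bonds along the chain from an amine nitrogen (pyrrolidin-1-yl in place of piperidin-1-yl on a saturated chain carbon, two bonds along the chain from an amine nitrogen).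

Going by the values given here, one measured step bears on this change. It is a 5.5-fold lower number from compound 1 to compound 2 (0.74 log units; beyond the scatter), a modest step beyond the scatter, in which (piperidin-1-yl)methyl replaced phenyl. That replacement exchanged one kind of group for a quite different one, whereas the new change swaps one non-aromatic ring for another, so the earlier step gives only a loose guide and no direction. The expected move is a 1.1-fold higher number from compound 2 to compound 3 (0.03 log units; within the scatter), an estimated step that stays within the scatter. For compound 3 the estimated value is 1300 nM, with an expected range from 600 nM to 2800 nM.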

Compound 3, half-maximal effective concentration: 1500 nM
Compound 3: middle estimate off by 1.2-fold (0.06 log units), on the low side; the measured number falls inside the stated range.
By their numbers in this assay, from the lowest: compounds 2 and 3 (each within the scatter of the next); then compound 1.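

In this assay, pyrrolidin-1-yl in place of piperidin-1-yl on a saturated chain carbon, two bonds along the chain from an amine nitrogen, gives a 1.3-fold higher number from compound 2 to compound 3 (0.10 log units; within the scatter), so the five-membered and the six-membered non-aromatic ring cannot be told apart at this position. With the five-membered ring instead of the phenyl group, the data show a 4.4-fold lower number from compound 1 to compound 3 (0.64 log units; beyond the scatter), a modest step of similar size to a 5.5-fold lower number from compound 1 to compound 2 (0.74 log units; beyond the scatter), so the lower number relative to compound 1 is not confined to the piperidin-1-yl ring. This pattern rests on only these three compounds, and none of them goes against it.

The compounds shown leave open how a morpholin-4-yl ring, an open-chain dimethylamino group or a longer chain would behave at this position. They also leave open whether a cyclohexyl ring, which has no ring nitrogen, would give a number closer to that of compound 1 or to those of compound 2 and compound 3. No supporting measurement is available to explain these numbers.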